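From Pyridin-3-yl to 1H-Pyrazol-1-yl on a Shared Core

This account rests on a few compounds, and the source may have more. Where it says the series, first, only, none or still open, it means among the compounds named here.

Three compounds share one core. Compound 1 `c1ccc(-c2ccc(CCc3nc(CC4CCCC4)c[nH]3)cc2)nc1` gives 98 nM in a functional assay on HEK293 cells for agonist activity at Bombesin receptor subtype-3 (Homo sapiens), read by luminescence and calcium flux, with a stated time of 10 min; a lower number here means that less compound is needed, a higher number that more compound is needed for the effect; compound 2 `CCC(C)(C)Cc1c[nH]c(CCc2ccc(-c3cccnc3)cc2)n1` gives 98 nM, and compound 3 `CCC(C)(C)Cc1c[nH]c(CCc2ccc(-n3ccnn3)cc2)n1` gives 93 nM. Among the measured compounds shown here, compound 2 thus stands level with compound 1, the two together the highest of the three numbers, and its only single-change step, a 1.1-fold lower number from compound 2 to compound 3 (0.02 log units; within the scatter), is within the scatter. Compound 4 `CCC(C)(C)Cc1c[nH]c(CCc2ccc(-n3cccn3)cc2)n1` differs from compound 2 by 1H-pyrazol-1-yl in place of pyridin-3-yl on an aromatic carbon. For the measured compounds named here, the one measured step that bears on this is the one from compound 2 to compound 3, where a five-membered aromatic ring likewise replaced pyridin-3-yl and the number stayed within the scatter. For compound 4 a similar outcome is expected, a 1.0-fold lower number from compound 2 to compound 4 (0.01 log units; within the scatter), nothing beyond the scatter. Compound 4 is therefore estimated at 95 nM, between 45 nM and 200 nM.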

Compound 4, half-maximal effective concentration: 106 nM
Beside the measured number, compound 4's estimate is 1.1-fold (0.05 log units) below it; measured number inside the range.
By their numbers in this assay, from the lowest: compounds 3, 1, 2 and 4 (each within the scatter of the next).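

Putting 1H-pyrazol-1-yl in place of pyridin-3-yl gives a 1.1-fold higher number from compound 2 to compound 4 (0.03 log units; within the scatter) and so makes a second five-membered aromatic ring that this position accepts with no change beyond the scatter. Exchanging one five-membered ring for the other gives a 1.1-fold higher number from compound 3 to compound 4 (0.06 log units; within the scatter) and shows that 1H-pyrazol-1-yl and 1H-1,2,3-triazol-1-yl cannot be told apart here. No available evidence explains this flat result. The compounds shown leave open whether a different kind of group at this position, such as an amine or a carboxylic acid, would move the number beyond the scatter.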